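The compounds below may be only part of what the source reports. "The series", "measured", "known", "first", "only" and "open" are said of these compounds alone.

Three compounds share one core and differ only in the aryl group on the carbonyl carbon of the amide. Compound 1 `O=C(Nc1ccc(Cl)c(-c2nnc3c(Cl)cccn23)c1)c1cccc(Cl)c1` carries a 3-chlorophenyl there, and in a functional assay on MDA-MB-468 cells (Homo sapiens) for antiproliferative activity, read by MTT assay, with a stated time of 72 h (a higher number here means a weaker inhibitor, a lower number a stronger inhibitor), compound 1 gives 54800 nM. Compound 2 `O=C(Nc1ccc(Cl)c(-c2nnc3c(Cl)cccn23)c1)c1ccccc1Cl` carries a 2-chlorophenyl; in this assay compound 2 reaches only the limit of the assay at > 100000 nM, so no number is known for it. Compound 3 `Cc1cc(Cl)ccc1C(=O)Nc1ccc(Cl)c(-c2nnc3c(Cl)cccn23)c1` carries a 4-chloro-2-methylphenyl, and in this assay compound 3 gives 34300 nM, the lowest of the two numbers, with compound 1 nearest: a 1.6-fold lower number from compound 1 to compound 3 (0.20 log units; within the scatter). Against compound 2 the gap is larger, an at least 2.9-fold lower number from compound 2 to compound 3 (0.46 log units; beyond the scatter), while an at least 1.8-fold higher number from compound 1 to compound 2 (0.26 log units; that floor lies within the scatter).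

Compound 4 `O=C(Nc1ccc(Cl)c(-c2nnc3c(Cl)cccn23)c1)c1ccccn1` is not yet measured. It differs from compound 3 in one place: pyridin-2-yl in place of 4-chloro-2-methylphenyl on a carbonyl carbon. The measured steps all concern the aryl group on the same carbonyl carbon, and they were small, with one of them hidden behind (the limit of > 100000 nM in this assay, at which 1 of the 3 values shown sits). None of them removes the chlorine or puts a hetero atom into the ring, so they set only a loose frame. Compound 4 is expected to sit near or somewhat above compound 3, an expected step of a 1.7-fold higher number from compound 3 to compound 4 (0.24 log units; within the scatter), with a real chance that only a limit is reported. For compound 4 in this assay the estimate is 60000 nM, expected between 20000 nM and 130000 nM.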

Compound 4, half-maximal inhibitory concentration: > 100000 nM
Compound 4: a limit, no number; the forecaster's own chance of this, stated with the estimate: 45%; middle value at least 1.6-fold (0.22 log units) away from the limit.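

Pyridin-2-yl is the first group on this carbonyl carbon with a hetero atom in its ring and with no chlorine, and in this assay its entry gives an at least 2.9-fold higher number from compound 3 to compound 4 (0.46 log units; beyond the scatter), which is only a floor on the true step. Set against the 3-chlorophenyl group, the same position gives an at least 1.8-fold higher number from compound 1 to compound 4 (0.26 log units; that floor lies within the scatter), so this floor alone does not separate the two groups beyond the scatter. Compound 4 stands at a limit, not at a number, as compound 2 does, and the step between these two cannot be read: the limit of > 100000 nM in this assay, at which 2 of the 4 values shown sit.

The compounds shown leave open whether the ring nitrogen or the loss of the chlorine carries the step from the 4-chloro-2-methylphenyl group, as this change makes both at once, and a plain phenyl or a chloropyridinyl group on the same carbonyl carbon would pull the two apart. Also open, going by these compounds, is how an amine, a carboxylic acid or a longer alkyl chain on that aryl ring would read in this assay, where only compound 1 and compound 3 have so far given numbers.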